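Swapping an ether side chain for an amine, watching toxicity

The source may report more compounds than this note shows. Statements on the series, on what has been measured and on what is new or still open speak of the compounds shown alone.

Compound 1 `COCCOc1nc(N)nc2c1ncn2/C=C1/CC1(CO)CO` is the starting point of this comparison. In an ADME assay on HFF cells (Homo sapiens) for cytotoxicity, with a stated time of 8 days (on this read-out higher numbers stand for lower toxicity in this test and lower numbers for higher toxicity in this test), compound 1 gives > 300000 nM and that figure is a limit of the assay rather than a measured number. Compound 2 `Nc1nc(NCc2ccccc2)c2ncn(/C=C3/CC3(CO)CO)c2n1` differs from compound 1 by a benzylamino in place of 2-methoxyethoxy on an aromatic carbon. In this assay compound 2 gives > 300000 nM and that too is a limit. The step that the two limits leave unreadable from compound 1 to compound 2 therefore cannot be sized. Both values sit at the limit of > 300000 nM in this assay, at which 2 of the 2 values shown sit, so no real difference between the two compounds is visible.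

Compound 3 `CC(C)Nc1nc(N)nc2c1ncn2/C=C1/CC1(CO)CO` has not yet been measured. It differs from compound 1 as follows: isopropylamino in place of 2-methoxyethoxy on an aromatic carbon. For the measured compounds named here, the only measured step, from compound 1 to compound 2, also replaces the 2-methoxyethoxy with a nitrogen-bearing group, yet its size is unreadable. With both measured values at the same limit, the expectation for compound 3 is that it too is reported at that limit, and the expected step of a number no higher from compound 1 to compound 3 (the limit leaves the size open) is none beyond the scatter. Compound 3 is estimated at 300000 nM with a range from 100000 nM to 1000000 nM.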

Compound 3, half-maximal cytotoxic concentration: > 300000 nM
Compound 3 was reported as a limit; the forecaster's own chance of this, stated with the estimate: 85%; the middle value sits exactly at the limit.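

Compound 3 adds no readable step: its comparisons with compound 1 and with compound 2 cannot be sized, as all three compounds sit at one limit rather than at measured numbers: the limit of > 300000 nM in this assay, at which 3 of the 3 values shown sit.

The compounds shown leave open whether the 2-methoxyethoxy, benzylamino and isopropylamino groups differ at all in toxicity in this assay.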